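Chloro to cyano at the limit of the assay

The source may report more compounds than this note shows. Statements on the series, on what has been measured and on what is new or still open speak of the compounds shown alone.

In an ADME assay on HeLa cells (Homo sapiens) for inhibition, read by MTT assay, with a stated time of 48 h (a higher number here means a weaker inhibitor, a lower number a stronger inhibitor), compound 1 (`O=C(/C=C/c1cn(Cc2ccccc2)c2ccccc12)CC(=O)C(=O)O`) gives > 40000 nM as a limit. Compound 2 (`O=C(/C=C/c1cn(Cc2ccc(Cl)cc2)c2ccccc12)CC(=O)C(=O)O`) gives > 40000 nM as a limit too. Among the measured compounds shown here, the one measured step is a step that the two limits leave unreadable from compound 1 to compound 2 and offers no size to carry forward. Compound 3 (`N#Cc1ccc(Cn2cc(/C=C/C(=O)CC(=O)C(=O)O)c3ccccc32)cc1`) has cyano in place of chloro on an aromatic carbon and is the next to be read. For the measured compounds named here, with the limit of > 40000 nM in this assay, at which 2 of the 2 values shown sit, as the only guide for compound 2 no step beyond the scatter is expected in this assay in either direction. The estimated step is a number no higher from compound 2 to compound 3 (the limit leaves the size open) and no larger. Compound 3 is expected at 40000 nM within a range from 18000 nM to 80000 nM and may again return only a limit.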

Compound 3, half-maximal inhibitory concentration: > 40000 nM
Compound 3 ended at the assay's limit (the forecaster's own chance of this, stated with the estimate: 75%); the middle value sits exactly at the limit.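

No step can be read among compound 1, compound 2 and compound 3, since all of them sit at the same limit: the limit of > 40000 nM in this assay, at which 3 of the 3 values shown sit. The compounds shown leave open how strongly each inhibits and whether chloro or cyano makes any difference.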